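This account rests on a few compounds, and the source may have more. Where it says the series, first, only, none or still open, it means among the compounds named here.

Measured in an ADME assay on NIH3T3 cells (Mus musculus) for cytotoxicity, with a stated time of 72 h; a lower number here means a stronger inhibitor, a higher number a weaker inhibitor:
- compound 1 `OC[C@H]1O[C@@H](n2cnc3c(NCc4ccc(F)cc4)ncnc32)[C@H](O)[C@@H]1O`: 44300 nM
- compound 2 `OC[C@H]1O[C@@H](n2cnc3c(NCc4ccc(Br)cc4)ncnc32)[C@H](O)[C@@H]1O`: > 166000 nM, a limit and not a number

Compound 2 stands at the limit of > 166000 nM in this assay, at which 1 of the 2 values shown sits. Compound 3 `COc1cccc(CNc2ncnc3c2ncn3[C@@H]2O[C@H](CO)[C@@H](O)[C@H]2O)c1` differs from it as follows: 3-methoxyphenyl in place of 4-bromophenyl on a saturated chain carbon bound to a nitrogen on an aromatic ring. In words, 3-methoxyphenyl takes the place of 4-bromophenyl on a saturated chain carbon bound to a nitrogen on an aromatic ring. Among the compounds with values here, one measured step bears on this, an at least 3.7-fold higher number from compound 1 to compound 2 (0.57 log units; beyond the scatter), which is beyond the scatter. It concerns bromo and fluoro, not methoxy, so it guides only loosely. With the bromo gone, a modest move back toward compound 1 at 44300 nM is expected, to a lower number in this assay. The expected change is an at least 2.0-fold lower number from compound 2 to compound 3 (0.31 log units; beyond the scatter). Compound 3 is estimated at 80000 nM, with an expected range of 25000 nM to 166000 nM.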

Compound 3, half-maximal inhibitory concentration: > 166000 nM
Compound 3 gave a limit, no number; the forecaster's own chance of this, stated with the estimate: 30%; at least 2.0-fold (0.31 log units) between middle value and limit.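

Compound 3 gives a limit and not a number in this assay, and it joins compound 2 there: the limit of > 166000 nM in this assay, at which 2 of the 3 values shown sit. The higher number relative to compound 1 therefore does not depend on bromo, since 3-methoxyphenyl in place of 4-fluorophenyl gives an at least 3.7-fold higher number from compound 1 to compound 3 (0.57 log units; beyond the scatter). The step between compound 2 and compound 3 cannot be read, as both values are limits.

Which of 4-bromophenyl and 3-methoxyphenyl gives the higher number stays open. So does whether an amine or a carboxylic acid on this saturated chain carbon would give a number lower than that of compound 1.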